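Changing the end group of compound 2

The compounds below may be only part of what the source reports. "The series", "measured", "known", "first", "only" and "open" are said of these compounds alone.

- compound 1 `Cc1ccc(-c2ccsc2S(=O)(=O)NCCNC(=O)Nc2ccc([N+](=O)[O-])cc2)c(Oc2ccc(O)c(O)c2)c1` gives 3900 nM here
- compound 2 `Cc1ccc(-c2ccsc2S(=O)(=O)NCCNC(=S)Nc2ccc([N+](=O)[O-])cc2)c(Oc2ccc(O)c(O)c2)c1` gives 2900 nM here

Both values come from a functional assay on HL-60 cells (Homo sapiens) for inhibition, read by CCK-8 assay, with a stated time of 48 h (on this read-out higher numbers stand for weaker inhibition and lower numbers for stronger inhibition), and lie within the usual scatter of each other, so compound 2 cannot be told apart from compound 1. Compound 3 (`Cc1ccc(-c2ccsc2S(=O)(=O)NCCNC(=O)Nc2cccc([N+](=O)[O-])c2)c(Oc2ccc(O)c(O)c2)c1`) differs from compound 2 by one change (a group of 12 heavy atoms (7 carbon, 2 nitrogen, 3 oxygen; one six-membered aromatic ring of carbon only) in place of a group of 12 heavy atoms (7 carbon, 2 nitrogen, 2 oxygen, 1 sulfur; one six-membered aromatic ring of carbon only), on an amine nitrogen) on an amine nitrogen, where (3-nitrophenyl)carbamoyl enters. Within the data shown here, the only measured step (a 1.3-fold lower number from compound 1 to compound 2 (0.13 log units; within the scatter)) is small and covers just part of this change. Among the measured compounds shown here, no measured compound carries this group, so the range stays wide. For compound 3 the expected step is a 1.2-fold higher number from compound 2 to compound 3 (0.08 log units; within the scatter) in this assay and none beyond the scatter is expected. The estimated value of compound 3 is 3500 nM within a range from 1500 nM to 8000 nM as a rough expectation.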

Compound 3, half-maximal inhibitory concentration: 6000 nM
Compound 3: middle estimate off by 1.7-fold (0.23 log units), on the low side, and the stated range covers the measured number.
By their numbers in this assay, from the lowest: compounds 2, 1 and 3 (each within the scatter of the next, the first and the last beyond it).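

Putting 3-nitrophenyl in place of 4-nitrophenyl gives a 1.5-fold higher number from compound 1 to compound 3 (0.19 log units; within the scatter) in this assay, so this swap alone leaves the two compounds indistinguishable. The step of a 2.1-fold higher number from compound 2 to compound 3 (0.32 log units; beyond the scatter) does pass the scatter, but only modestly, and it combines that swap with oxygen replacing sulfur, so neither difference can be credited separately. No available evidence explains these numbers. Still open, from the compounds shown here alone, is how the compound would behave with an amine or a carboxylic acid in place of the nitro group on this ring.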